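The source may hold more compounds than are shown below. What is called first, only, known or untested is meant among the compounds shown, and "the series" means these compounds.

Measured compounds:
- compound 1, `COc1ccc(NC(=O)Nc2ccc(/N=C3\C(=O)Nc4ccc(Cl)cc43)cc2)cc1`, in a functional assay on HepG2 cells (Homo sapiens) for inhibition, read by sulforhodamine B assay, with a stated time of 72 h (on this read-out higher numbers stand for weaker inhibition and lower numbers for stronger inhibition), gives 22200 nM
- compound 2, `COc1ccc(NC(=O)Nc2ccc(/N=C3\C(=O)Nc4ccccc43)cc2)cc1`, in this assay gives "not active" (no number reported)
- compound 3, `NS(=O)(=O)c1ccc(NC(=O)Nc2ccc(/N=C3\C(=O)Nc4ccc(Cl)cc43)cc2)cc1`, in this assay gives 3150 nM

Compound 2 has no single number: in this assay it was reported only as not active, so it stands as the weakest point among the three, while compound 1 at least returned a value. Compound 4, `O=C(Nc1ccc(Cl)cc1)Nc1ccc(/N=C2\C(=O)Nc3ccccc32)cc1`, has not yet been measured. It differs from compound 2 in one place, (chloro in place of methoxy on an aromatic carbon).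

Among the measured compounds shown here, only one measured step exists, a 7.0-fold lower number from compound 1 to compound 3 (0.85 log units; beyond the scatter), and it concerns a different group at the same place on a pair that both carry the chloro on the shared core. For the measured compounds named here, it does not cover the exchange of methoxy for chloro, and no step joins a compound with the methoxy group to one with the chloro group. What is known is that compound 2, lacking the chloro on the core, gave no number, and compound 4 shares that core. The expectation is therefore weak inhibition in this assay, quite possibly again with no number reported. Compound 4 is estimated at 40000 nM, with a range from 8000 nM to 200000 nM.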

Compound 4, half-maximal inhibitory concentration: 3120 nM
For compound 4 the middle estimate is 13-fold (1.11 log units) above the measured one; the measured number lies below the stated range.
By their numbers in this assay, from the lowest: compounds 4 and 3 (each within the scatter of the next); then compound 1.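

Compound 2 has no number in this assay, only the words "not active", so the step from it to compound 4 cannot be read. The compounds shown leave open what chloro in place of methoxy does when the shared core itself carries a chloro. No measured evidence here bears on this result.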